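Clearance of an amide and its 1,3,4-thiadiazol-2-yl relative

The source may hold more compounds than are shown below. What is called first, only, known or untested is meant among the compounds shown, and "the series" means these compounds.

- Compound 1 `Nc1nccn2c1c(-c1ccc3ccc(-c4ccccc4)nc3c1F)nc2[C@H]1CC[C@H](C(=O)O)CC1` gives 26 mL/min/kg
- Compound 2 `Nc1nccn2c1c(-c1ccc3ccc(-c4ccccc4)nc3c1F)nc2[C@H]1CC[C@H](C(N)=O)CC1` gives 38 mL/min/kg

Both values come from an in vivo ADME assay on the whole organism for pharmacokinetics, with Mus musculus as the target, at a dose of 5 mg/kg by the intravenous route (a higher number here means faster removal of the compound, a lower number slower removal), and report how fast the body removes each compound. Compound 2 stands within the usual scatter of compound 1, so these two numbers cannot be ranked. Among the measured compounds shown here, the only measured step, amino in place of hydroxy on a carbonyl carbon, is small (a 1.5-fold higher number from compound 1 to compound 2 (0.16 log units; within the scatter)).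

Compound 3 `Nc1nccn2c1c(-c1ccc3ccc(-c4ccccc4)nc3c1F)nc2[C@H]1CC[C@H](C(=O)Nc2nncs2)CC1` differs from compound 2 by having 1,3,4-thiadiazol-2-yl in place of hydrogen on an amide-type nitrogen. For the measured compounds named here, the measured step also changed what sits on the carbonyl carbon, but no measured compound carries a ring at this place, so it is only a weak guide. It gives no reason to expect a direction, and the expected change is no larger than the scatter (a 1.1-fold lower number from compound 2 to compound 3 (0.04 log units; within the scatter)). The estimate therefore starts from compound 2 (38 mL/min/kg), with a wide range to reflect how little the data show. Compound 3 is expected at 35 mL/min/kg (estimated range 14 mL/min/kg to 80 mL/min/kg).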

Compound 3, clearance: 73 mL/min/kg
Beside the measured number, compound 3's estimate is 2.1-fold (0.32 log units) below it; measured number inside the range.
By their numbers in this assay, from the lowest: compounds 1, 2 and 3 (each within the scatter of the next, the first and the last beyond it).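

Placing a ring on the amide-type nitrogen gives the first view of a larger group at this position in this assay. The change from carbamoyl to (1,3,4-thiadiazol-2-yl)carbamoyl, taken alone, stays within the scatter (a 1.9-fold higher number from compound 2 to compound 3 (0.28 log units; within the scatter)), so compound 2 and compound 3 cannot be ranked, but replacing hydroxy on the carbonyl carbon with (1,3,4-thiadiazol-2-yl)amino gives the first difference in this set that lies beyond the scatter, albeit a modest one (a 2.8-fold higher number from compound 1 to compound 3 (0.45 log units; beyond the scatter)). Nothing available here explains why clearance responds in this way to the change.

The compounds shown cannot assign that difference to the amide link or to the ring, since compound 2 lies within the scatter of both compound 1 and compound 3. They also leave open whether a methyl group or a phenyl ring on the same amide-type nitrogen would give a number close to that of compound 2 or of compound 3.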